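Trimming One Carbon in a Seizure-Model Series

The source may report more compounds than this note shows. Statements on the series, on what has been measured and on what is new or still open speak of the compounds shown alone.

Two measured compounds set the scene. Compound 1 `CC(C(=O)N1CCN(c2cccc(Cl)c2)CC1)N1C(=O)CCC1=O` and compound 2 `CCC(C(=O)N1CCN(c2cccc(C)c2)CC1)N1C(=O)CCC1=O` were both tested in a functional assay on the whole organism (strain Swiss) with Mus musculus as the target, in the maximal electroshock model, with a stated time of 0.5 h, at a dose of 300 mg/kg by the intraperitoneal route; on this read-out lower numbers stand for a weaker effect and higher numbers for a stronger effect at the one dose given. Compound 1 gives 100% and compound 2 gives 100%; the two values are level at the digits shown, so compound 2 stands with compound 1, within the scatter. Compound 3 `Cc1cccc(N2CCN(C(=O)C(C)N3C(=O)CCC3=O)CC2)c1` has not yet been tested. It differs from compound 2 in one place: hydrogen in place of methyl on a saturated chain carbon, two bonds along the chain from an amide-type nitrogen in a ring and a carbonyl carbon. Within the data shown here, no step between measured compounds of this kind has been recorded, so the size of such a change is not yet known here. Both measured compounds reach the top of the read-out, and the expected step is no change at the digits printed from compound 2 to compound 3 (within the scatter), no change beyond the scatter. Compound 3 is therefore expected to give about 100%, with a range from 80% to 100%.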

Compound 3, a percentage reported as activity, at one dose (the size of the read-out at that dose, not a potency): 50%
The estimate for compound 3 lay 50 percentage points above the measured number; the measured number lies below the stated range.
By their numbers in this assay, from the lowest: compound 3; then compounds 1 and 2 (each within the scatter of the next).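

In this assay, hydrogen in place of methyl on the saturated chain carbon, a change that can also be read as ethyl to methyl, gives a number 50 percentage points lower from compound 2 to compound 3 (beyond the scatter), so this position is not a silent one when the aromatic methyl is present. Methyl in place of chloro on the aromatic carbon gives a number 50 percentage points lower from compound 1 to compound 3 (beyond the scatter), so the aromatic group matters as well when the chain is the shorter one. The two earlier compounds, level at the top of the read-out, hid both effects: each change counts here only in the setting of compound 3, and the two sites cannot be judged apart from each other.

Nothing available bears on the cause of either step. From the compounds shown here alone, whether a propyl chain at the saturated carbon, or a fluoro or methoxy group on the aromatic carbon, would hold the top of the read-out remains open.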